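Replacing a Sulfamide with a Trifluoroacetamide: Lipophilicity Outlook

A few compounds are considered here, and "the series" means these few. Any claim that something is new, unique, unknown or untested is made for them only; others in the source may bear on it.

Three compounds on a shared core have been measured in a physicochemical assay for lipophilicity, read by HPLC, measured as octanol-water partition; a higher number here means a more lipophilic compound, a lower number a more polar compound:

Compound 1, `O=C1CCC(=O)N1C[C@H]1CN(c2ccc(-n3cc(-c4ccccn4)cn3)c(F)c2)C(=O)O1`, gives 1.58.
Compound 2, `O=C1O[C@@H](Cn2ccnn2)CN1c1ccc(-n2cc(-c3ccccn3)cn2)c(F)c1`, gives 2.
Compound 3, `CN(C)S(=O)(=O)NC[C@H]1CN(c2ccc(-n3cc(-c4ccccn4)cn3)c(F)c2)C(=O)O1`, gives 1.38.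

Compound 3 holds the lowest of the three numbers in this assay. Its nearest neighbour is compound 1, reached by a number 0.20 log units lower from compound 1 to compound 3 (within the scatter); its furthest is compound 2, reached by a number 0.62 log units lower from compound 2 to compound 3 (beyond the scatter). The remaining pair shows a number 0.42 log units higher from compound 1 to compound 2 (beyond the scatter).

Compound 4, `O=C1O[C@@H](CNC(=O)C(F)(F)F)CN1c1ccc(-n2cc(-c3ccccn3)cn2)c(F)c1`, is not yet measured. It differs from compound 3 in one place: (trifluoromethyl)carbonyl in place of dimethylsulfamoyl on an amine nitrogen.

Within the data shown here, no measured step swaps exactly this pair of groups. The two steps that touch the (dimethylsulfamoyl)amino group of compound 3 both point the same way: leaving it for the 2,5-dioxopyrrolidin-1-yl group of compound 1 stays within the scatter, while leaving it for the 1H-1,2,3-triazol-1-yl group of compound 2 raises the number modestly. The group that enters in compound 4 carries fewer hydrogen-bond acceptors than the one that leaves, so a modest rise beyond the scatter is expected, a number 0.57 log units higher from compound 3 to compound 4 (beyond the scatter). For compound 4 the estimated value in this assay is 1.95, with a likely range from 1.55 to 2.35.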

Compound 4, partition coefficient: >= 1.78
Compound 4: no number, only a limit; the forecaster's own chance of this, stated with the estimate: 2%; the middle value lies beyond the limit too.
By their numbers in this assay, from the lowest: compounds 3 and 1 (each within the scatter of the next); then compound 2.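

In this assay, compound 4 gives only a limit and not a number: the limit of >= 1.78 in this assay, at which 1 of the 4 values shown sits.

Even so, the limit is enough to give this amine nitrogen, on its saturated chain carbon, its first readable step: (trifluoromethyl)carbonyl in place of dimethylsulfamoyl gives a number at least 0.40 log units higher from compound 3 to compound 4 (beyond the scatter). Earlier steps had exchanged the whole (dimethylsulfamoyl)amino group, whereas this one keeps the amine nitrogen and changes only what it carries. The comparison with the 2,5-dioxopyrrolidin-1-yl group is less firm, as a number at least 0.20 log units higher from compound 1 to compound 4 (that floor lies within the scatter) sets a floor that does not separate the two compounds, and the step between compound 2 and compound 4 cannot be read.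

The compounds shown leave open where the actual number for compound 4 lies, and so how far the ((trifluoromethyl)carbonyl)amino group stands from the 1H-1,2,3-triazol-1-yl group of compound 2. They also leave open how much of the step goes with the three fluorine atoms, a question that an acetyl group on the same amine nitrogen would address, with a methanesulfonyl group as the matching comparison for the sulfur-bearing side.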